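Working notes: from compound 1 to compound 3

The source may report more compounds than this note shows. Statements on the series, on what has been measured and on what is new or still open speak of the compounds shown alone.

- compound 1 `O=C(NO)c1ccc(/C=C/c2ccnc(-c3ccccc3O)c2)cc1` gives 1450 nM
- compound 2 `COc1ccc(-c2cc(/C=C/c3ccc(C(=O)NO)cc3)ccn2)cc1` gives 3560 nM

In a functional assay on HCT-116 cells (Homo sapiens) for antiproliferative activity, read by CellTiter-Glo, with a stated time of 72 h (a lower number here means a stronger inhibitor, a higher number a weaker inhibitor), compound 1 holds the lower of the two numbers, and the gap is a 2.5-fold higher number from compound 1 to compound 2 (0.39 log units; beyond the scatter). Compound 3 `O=C(/C=C/c1ccc(/C=C/c2ccnc(-c3ccccc3O)c2)cc1)NO` carries 2-(hydroxycarbamoyl)ethenyl in place of hydroxycarbamoyl on an aromatic carbon, para to a large group (2-(hydroxycarbamoyl)ethenyl in place of hydroxycarbamoyl on an aromatic carbon). Among the compounds with values here, the one measured step changes a different group, so it only suggests a modest scale and gives no direction. Within the data shown here, a moderate move to a lower number in this assay is expected, as a judgement that no measurement yet supports. The expected change is a 2.6-fold lower number from compound 1 to compound 3 (0.42 log units; beyond the scatter). Compound 3 is estimated at 550 nM, within an expected range of 120 nM to 2200 nM.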

Compound 3, half-maximal inhibitory concentration: > 10000 nM
Compound 3: only a limit was reported; the forecaster's own chance of this, stated with the estimate: 3%; middle value at least 18-fold (1.25 log units) from the limit.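

In this assay, compound 3 reads > 10000 nM, which is a limit and not a number. At this position on the aromatic carbon, para to a large group, 2-(hydroxycarbamoyl)ethenyl in place of hydroxycarbamoyl gives an at least 6.8-fold higher number from compound 1 to compound 3 (0.83 log units; beyond the scatter), so this change costs more than the earlier change at the other end of the core, and its true size stays bounded on one side only: the limit of > 10000 nM in this assay, at which 1 of the 3 values shown sits.

As far as these compounds go, whether the loss goes with the added double bond or the added length stays open. A saturated 2-(hydroxycarbamoyl)ethyl chain or a 2-aminophenyl amide in place of hydroxycarbamoyl on the core of compound 1 would bear on this.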